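The source may report more compounds than this note shows. Statements on the series, on what has been measured and on what is new or still open speak of the compounds shown alone.

For the measured compounds named here, three compounds came to an ADME assay on HeLa cells (Homo sapiens) for inhibition, read by MTT assay, with a stated time of 48 h (a higher number here means a weaker inhibitor, a lower number a stronger inhibitor), and only one gave a reading. Compound 1 `CCOC(=O)C(=O)CC(=O)/C=C/c1cn(Cc2ccc(C#N)cc2)c2ccccc12` has the entry "not determined" (no result reported). Compound 3 `CCOC(=O)C(=O)CC(=O)/C=C/c1cc(C(=O)c2ccccc2)cn1Cc1ccccc1` has the entry "not determined" (no result reported). Compound 2 `CCOC(=O)C(=O)CC(=O)/C=C/c1cc(C(=O)c2ccccc2F)c[nH]1` stands at > 40000 nM, which is a limit of the assay and not a number. This is the limit of > 40000 nM in this assay, at which 1 of the 3 values shown sits. Compound 4 `O=C(/C=C/c1cc(C(=O)c2ccccc2F)c[nH]1)CC(=O)C(=O)O` differs from compound 2 by one change, hydrogen in place of ethyl on an oxygen next to a carbonyl group. Going by the values given here, no measured pair shows what this change does, so no shift beyond the usual scatter is expected. The expected step, a step that the limit leaves unreadable from compound 2 to compound 4, is therefore small. In this assay compound 4 is estimated at 45000 nM, with an expected range from 15000 nM to 120000 nM.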

Compound 4, half-maximal inhibitory concentration: > 40000 nM
Compound 4: only a limit was reported; the forecaster's own chance of this, stated with the estimate: 75%; the middle value lies beyond the limit too.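

No step from compound 2 to compound 4 can be read, as both compounds rest at a limit and not at a number: the limit of > 40000 nM in this assay, at which 2 of the 4 values shown sit.

The compounds shown leave open whether hydrogen in place of ethyl on an oxygen next to a carbonyl group changes the reading in this assay at all.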